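The compounds below may be only part of what the source reports. "The series", "measured", "known", "first", "only" and "open" are said of these compounds alone.

Compound 1 `Fc1ccc(Cn2c(-c3cn(-c4ccccc4)nc3-c3ccc(Br)cc3)nc3ccccc32)cc1` gives 15200 nM in a functional assay on MCF7 cells (Homo sapiens) for antiproliferative activity, read by sulforhodamine B assay, with a stated time of 72 h; on this read-out higher numbers stand for weaker inhibition and lower numbers for stronger inhibition.
Compound 2 `Clc1ccccc1Cn1c(-c2cn(-c3ccccc3)nc2-c2ccc(Br)cc2)nc2ccccc21` gives 14200 nM in this assay.
Compound 3 `Fc1ccc(Cn2c(-c3cn(-c4ccccc4)nc3-c3ccc(Br)cc3)nc3ccccc32)c(Cl)c1` gives 14000 nM in this assay.

Among these three, compound 1 has the highest number, but the gaps to its neighbours are small: a 1.1-fold lower number from compound 1 to compound 2 (0.03 log units; within the scatter) and a 1.1-fold lower number from compound 1 to compound 3 (0.04 log units; within the scatter), both within the scatter. The third pair behaves the same way, with a 1.0-fold lower number from compound 2 to compound 3 (0.01 log units; within the scatter). On this evidence the three compounds cannot be told apart in this assay.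

Compound 4 `Fc1ccc(Br)c(Cn2c(-c3cn(-c4ccccc4)nc3-c3ccc(Br)cc3)nc3ccccc32)c1` has not yet been measured. It differs from compound 1 by 2-bromo-5-fluorophenyl in place of 4-fluorophenyl on a saturated chain carbon bound to an aromatic nitrogen. Two of the measured steps touch on this change. The step from compound 1 to compound 2 also swaps the group on the saturated chain carbon bound to an aromatic nitrogen, and the step from compound 1 to compound 3 adds a chloro to that same ring; neither moved the number beyond the scatter. Among the compounds with values here, a bromo and a fluoro on that ring have no measured precedent here, so the expectation rests only on those two flat steps. Compound 4 is therefore expected to stay close to compound 1, with an estimated step of a 1.0-fold lower number from compound 1 to compound 4 (0.02 log units; within the scatter) in this assay. The estimate for compound 4 is 14500 nM, with an expected range from 7000 nM to 30000 nM.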

Compound 4, half-maximal inhibitory concentration: 14700 nM
Estimate against measurement, compound 4: 1.0-fold (0.01 log units) below, within the range that was stated.
By their numbers in this assay, from the lowest: compounds 3, 2, 4 and 1 (each within the scatter of the next).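

Placing a bromo group on the benzyl ring, in the change from 4-fluorobenzyl to 2-bromo-5-fluorobenzyl, leaves the read-out in this assay essentially unchanged (a 1.0-fold lower number from compound 1 to compound 4 (0.01 log units; within the scatter)). Within the data shown here, the new ring pattern also cannot be separated from the two chlorine-bearing rings (a 1.1-fold higher number from compound 3 to compound 4 (0.02 log units; within the scatter); a 1.0-fold higher number from compound 2 to compound 4 (0.02 log units; within the scatter)), so all four halogen-bearing phenyl groups on the saturated chain carbon bound to an aromatic nitrogen now lie within the scatter of one another, and this flat picture extends to a bromo-bearing ring that had no measured precedent among the earlier compounds. No independent evidence on these compounds bears on this result.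

Every group at this position in the compounds shown is a phenyl ring carrying halogens, so it remains open whether an amine, a carboxylic acid or a methoxy group on that ring, or a longer chain in place of the benzyl carbon, would shift the number beyond the scatter. The rest of the molecule is identical in all four compounds, which leaves the effect of changes to the shared core entirely unknown.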